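Adding a methoxyethyl chain to a core that shows no activity

The source may report more compounds than this note shows. Statements on the series, on what has been measured and on what is new or still open speak of the compounds shown alone.

Measured compounds:
Compound 1, `COc1cc(C(N)=O)cc2nc(NC(=O)c3ccccn3)n(CCCNC(=O)OCc3ccccc3)c12`, in an assay for activation of interferon regulatory factor 3 (Homo sapiens), read by a luciferase reporter, with a stated time of 20 h; a higher number here means that more compound is needed for the effect, a lower number that less compound is needed: > 100000 nM
Compound 2, `COc1cc(C(N)=O)cc2nc(NC(=O)c3cccnn3)n(CCCNC(=O)OCc3ccccc3)c12`, in this assay: > 100000 nM

Compound 1 carries a methoxy group on its core, a pyridin-2-yl carbonyl on the amide and a benzyl carbamate on the side chain. In this assay compound 1 gives only a limit, > 100000 nM, so no number is known for it. Compound 2 likewise gives only a limit in this assay, > 100000 nM. For the measured compounds named here, the sole measured step, a step that the two limits leave unreadable from compound 1 to compound 2, therefore cannot be read in size or direction; both values sit at the limit of > 100000 nM in this assay, at which 2 of the 2 values shown sit.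

Compound 3, `COCCCOc1cc(C(N)=O)cc2nc(NC(=O)c3ccccn3)n(CCCNC(=O)OCc3ccccc3)c12`, differs from compound 1 in one place: 2-methoxyethyl in place of hydrogen on a saturated chain carbon bound to an oxygen on an aromatic ring. Going by the values given here, no measured step touches this position, and the one step that is known concerns the carbonyl substituent and is itself unreadable. There is thus no basis to expect a change that rises out of the scatter; the expected step from compound 1 to compound 3 is a number no higher from compound 1 to compound 3 (the limit leaves the size open), most probably ending again at a limit. Compound 3 is estimated at 100000 nM in this assay, with a range from 20000 nM to 300000 nM.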

Compound 3, half-maximal effective concentration: > 100000 nM
Compound 3: only a limit was reported; the forecaster's own chance of this, stated with the estimate: 80%; the middle value sits exactly at the limit.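

In this assay compound 3 gives > 100000 nM, which is a limit and not a number. Compound 1 also stands at a limit, so no size or direction can be read for the step between compound 1 and compound 3. Every value shown sits at one limit: the limit of > 100000 nM in this assay, at which 3 of the 3 values shown sit. The compounds shown leave open whether any of them has measurable activity in this assay, and what effect the 2-methoxyethyl group has.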